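Biaryl substituent swap on a nitrile-bearing core

A few compounds are considered here, and "the series" means these few. Any claim that something is new, unique, unknown or untested is made for them only; others in the source may bear on it.

This account follows one pair of compounds from a series sharing a common core. Compound 3 has the structure `CC[C@@H](Nc1c(C#N)c(-c2ccc(-c3cccc(OC)c3)cc2)nc2cnccc12)C(N)=O`. In a physicochemical assay for lipophilicity, read by HPLC, at pH 7.5 (on this read-out lower numbers stand for lower lipophilicity and higher numbers for higher lipophilicity), compound 3 gives 2.7. Among the three compounds measured, compound 3 stands second highest. The nearest neighbour is compound 1, with structure `N#Cc1c(-c2ccc(Br)cc2)nc2cnccc2c1NCC(N)=O`, which in this assay gives 1.9, a value lying beyond the scatter below compound 3. The furthest is compound 2, with structure `CCCCC(Nc1c(C#N)c(-c2ccc(-c3ccccc3OCC)cc2)nc2cnccc12)C(N)=O`, which in this assay gives 3.6, lying beyond the scatter above compound 3.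

Compound 4, with structure `CC[C@@H](Nc1c(C#N)c(-c2ccc(-c3ccccc3COC)cc2)nc2cnccc12)C(N)=O`, has not yet been measured. Compared with compound 3 it differs in one place: 2-(methoxymethyl)phenyl in place of 3-methoxyphenyl on an aromatic carbon

Among the measured compounds shown here, no step between two measured compounds isolates this kind of change, so the expectation rests on the values of compounds 1 through 3 alone. Since compound 2 carries a larger substituted biaryl and gives 3.6, a small upward step is expected in this assay, at the edge of the scatter. The expected step from compound 3 to compound 4 is a number 0.20 log units higher from compound 3 to compound 4 (within the scatter). Compound 4 is therefore estimated at 2.9, with a range from 2.5 to 3.3.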

Compound 4, distribution coefficient: 2.6
Estimate against measurement, compound 4: 0.30 log units above, and the stated range covers the measured number.
By their numbers in this assay, from the lowest: compound 1; then compounds 4 and 3 (each within the scatter of the next); then compound 2.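

Among the compounds shown here, the swap of 3-methoxyphenyl for 2-(methoxymethyl)phenyl, on an aromatic carbon para to a large group, is the first change here that can be read at one place alone, and in this assay it comes to a number 0.10 log units lower from compound 3 to compound 4 (within the scatter) on the same shared core. At this position, then, the two substituents cannot be told apart on this read-out, although the entering group has 9 heavy atoms against 8 for the leaving one, with 1 hydrogen-bond acceptor, 0 donors and no net charge on each side. Nothing measured alongside these numbers offers an explanation for this result.

This single step changes both where the oxygen-bearing substituent stands on the outer ring and the chain that carries it, so the two changes cannot be read apart from the compounds shown. From the compounds shown here alone, whether the read-out would stay level with an amine or a carboxylic acid in the same place, or with a longer chain ending in an ether, remains open.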